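Thiourea and urea esters at the adenosine receptor: a small series

A few compounds are considered here, and "the series" means these few. Any claim that something is new, unique, unknown or untested is made for them only; others in the source may bear on it.

Measured compounds:
compound 1 `CCCOC(=O)C1=C(C)NC(=S)NC1c1ccoc1`: 4%
compound 2 `CC1=C(C(=O)OCC(C)C)C(c2ccoc2)NC(=S)N1`: 12%
compound 3 `CCCOC(=O)C1=C(C)N(C)C(=O)NC1c1ccsc1`: 2%

In an assay on membranes from CHO cells for displacement of a labelled ligand from adenosine receptor A1 (Homo sapiens), read by scintillation counting, with a stated time of 60 min, tested at 1 uM (a lower number here means less inhibition, a higher number more inhibition at the concentration tested (going by the name of the read-out)), compound 1 gives 4%, and compound 2 gives 12%. The two differ by methyl in place of hydrogen on a saturated chain carbon bound to two saturated chain carbons, and the step of a number 8 percentage points higher from compound 1 to compound 2 (within the scatter) stays within the scatter. Compound 3, with 2%, sits on a different core; the difference between its core and that of compound 1 is not broken down here.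

Compound 4 `CC1=C(C(=O)OCC(C)C)C(c2ccsc2)NC(=O)N1C` is not yet measured. It stands to compound 3 as compound 2 stands to compound 1: methyl in place of hydrogen on a saturated chain carbon bound to two saturated chain carbons, the same change made in the same place. Resting on the step from compound 1 to compound 2 and on the value of compound 3, 2%, the step of a number 6 percentage points higher from compound 3 to compound 4 (within the scatter) is expected to be small and within the scatter. Compound 4 is therefore estimated at 8% in this assay, between 0% and 20%.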

Compound 4, a percentage reported as inhibition, at one concentration (the size of the read-out at that concentration, not a potency): 8%
Compound 4: the middle estimate sits on the measured number at the digits printed; low and high end bracket the measured number.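

In this assay, replacing hydrogen with methyl, which turns propoxy into isobutoxy, gives a number 6 percentage points higher from compound 3 to compound 4 (within the scatter). Set beside the earlier step, the change reads alike on the two cores: the same change on two cores in this assay, a number 8 percentage points higher (within the scatter) from compound 1 to compound 2 and a number 6 percentage points higher (within the scatter) from compound 3 to compound 4, 2 percentage points apart, within the scatter of two such steps. Going by these compounds alone, this shows only that the change does little on either core at the single concentration tested; it does not show that methyl increases inhibition, nor how the change would carry over to a core with a larger read-out.

The compounds shown carry only propoxy or isobutoxy, so the effect of a longer chain or an amine there remains open. Also open, on these data alone, is whether a furan or thiophene ring matters on a matched core.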